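From a Methylamide to an Arylamide: an Untested Step

The source may report more compounds than this note shows. Statements on the series, on what has been measured and on what is new or still open speak of the compounds shown alone.

Of the compounds shown here, two have been measured in an assay on CHO-K1 cells for displacement of a labelled ligand from prostaglandin E2 receptor EP1 subtype (Homo sapiens); on this read-out higher numbers stand for weaker inhibition and lower numbers for stronger inhibition. Compound 1 `Cc1cc(C(=O)O)nn1C(C)c1cc(Cl)ccc1OCc1ccccc1` gives 10 nM. Compound 2 `CNC(=O)c1cc(C)n(Cc2cc(Cl)ccc2OCc2ccccc2)n1` gives 100 nM, the higher of the two numbers, with compound 1 a step lower that is beyond the scatter. Compound 3 `Cc1cc(C(=O)Nc2ccc(F)cc2)nn1Cc1cc(Cl)ccc1OCc1ccccc1` differs from compound 2 by 4-fluorophenyl in place of methyl on an amide-type nitrogen. Within the data shown here, no measured pair shows this change, so its size is unknown. In this assay the expected step is a modest one of a 1.7-fold lower number from compound 2 to compound 3 (0.22 log units; within the scatter). Compound 3 is estimated at 60 nM, within a range from 15 nM to 300 nM.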

Compound 3, half-maximal inhibitory concentration: 79.4 nM
Estimate against measurement, compound 3: 1.3-fold (0.12 log units) below, within the range that was stated.
By their numbers in this assay, from the lowest: compound 1; then compounds 3 and 2 (each within the scatter of the next).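

In this assay, the amide-type nitrogen accepts a far larger group without a change beyond the scatter: 4-fluorophenyl in place of methyl, bringing a six-membered aromatic ring, gives a 1.3-fold lower number from compound 2 to compound 3 (0.10 log units; within the scatter) and thus no real separation between the two amides. Among these compounds, this is the first reading of any change at this position. Nothing available explains why the two read alike.

Open, going by these compounds, is how a plain phenyl, a benzyl or a propyl chain on this nitrogen would read. On these data alone, compound 1, with its carboxylic acid, differs from these amides in more than one place, so what the amide itself contributes also remains open.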